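The compounds below may be only part of what the source reports. "The series", "measured", "known", "first", "only" and "open" are said of these compounds alone.

Working notes, series measured in a functional assay on KB cells (Homo sapiens) for inhibition, read by MTT assay, with a stated time of 24 h, tested at 0.1 ug/mL; a lower number here means less inhibition of growth, a higher number more inhibition of growth at the concentration tested:
compound 1 `O=C(CCCCC1CCSS1)Nc1ccc(OC(F)(F)F)cc1` gives 1.97%
compound 2 `O=C(CCCCC1CCSS1)Nc1ccc([N+](=O)[O-])c(C(F)(F)F)c1` gives 4.5%
compound 3 `O=C(CCCCC1CCSS1)Nc1ccccn1` gives "not active" (no number reported)

Compound 1 lies within the usual scatter of compound 2, and compound 3 has no number to compare. Compound 4 `O=C(CCCCC(S)CCS)Nc1ccc(OC(F)(F)F)cc1` is compound 1 with the ring opened: a group of 5 heavy atoms (3 carbon, 2 sulfur; no ring) in place of a group of 5 heavy atoms (3 carbon, 2 sulfur; one five-membered non-aromatic ring with 2 hetero atoms), on a saturated chain carbon, four bonds along the chain from a carbonyl carbon. 1,3-disulfanylpropyl has no ring, and the rest of the structure is unchanged. Going by the values given here, no measured pair isolates a single change, so the data give no guide to the size or direction of this step. No step beyond the scatter is expected in this assay. The expected change is a number 3 percentage points higher from compound 1 to compound 4 (within the scatter). Compound 4 is estimated at 5%, with an expected range from 0% to 14%.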

Compound 4, percent growth inhibition at one concentration: 7.27%
Compound 4: the middle estimate sits 2.3 percentage points below what was measured; the measured number falls inside the stated range.
By their numbers in this assay, from the lowest: compounds 1, 2 and 4 (each within the scatter of the next).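

In this assay, going by these compounds alone, the one change from the ring to 1,3-disulfanylpropyl, on a saturated chain carbon, four bonds along the chain from a carbonyl carbon, gives a number 5.3 percentage points higher from compound 1 to compound 4 (within the scatter) and is the only single-change step. At the one concentration tested, this position therefore does not separate the ring from the open form. No measured evidence bearing on this result is available.

Going by these compounds, whether an amine, a carboxylic acid or a longer chain at this place would give a step beyond the scatter stays open. Also open, on these data alone, is whether the same ring opening would give a similar result on the core of compound 2 or compound 3.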